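Aryl swap on the pyrazole series: chlorothiophene for methylpyridine

The source may report more compounds than this note shows. Statements on the series, on what has been measured and on what is new or still open speak of the compounds shown alone.

Measured so far in an assay on HEK293 cells for inhibition of Voltage-dependent N-type calcium channel subunit alpha-1B (Homo sapiens), read by fluorescence and calcium flux, with a stated time of 5 min; on this read-out lower numbers stand for stronger inhibition and higher numbers for weaker inhibition:
compound 1 `COc1ccccc1-n1nc(C2CC(C)(C)OC(C)(C)C2)cc1-c1ccc(C)nc1` gives 6 nM
compound 2 `COc1ccccc1-n1nc([C@@H]2CCO[C@@H](C(C)C)C2)cc1-c1ccc(Cl)cc1` gives 20 nM
compound 3 `COc1ccccc1-n1nc(C2CCOC(C)(C)C2)cc1-c1ccc(Cl)cc1` gives 2 nM

Compound 1 stands second highest of the three numbers in this assay. Its nearest neighbour is compound 3, whose number is lower, a gap beyond the scatter; compound 2 lies furthest, with a higher number, also beyond the scatter. Compound 3 carries the lowest number of the three.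

Among the compounds with values here, the single measured step that differs in one place, a 10-fold lower number from compound 2 to compound 3 (1.00 log units; beyond the scatter), concerns the oxane substituent only. Within the data shown here, the change now in question, (5-chlorothiophen-3-yl in place of 6-methylpyridin-3-yl on an aromatic carbon), concerns the other aryl group on the shared core, and no measured pair differs at that position alone; compound 1 and compound 3 differ both there and on the oxane, so their values show nothing clean about the aryl group on its own.

Compound 4 `COc1ccccc1-n1nc(C2CC(C)(C)OC(C)(C)C2)cc1-c1csc(Cl)c1` is to be measured in this assay. Among the measured compounds shown here, with no step bearing on the aryl change, the expectation for compound 4 is a number close to compound 1, with no step beyond the scatter, a 1.3-fold higher number from compound 1 to compound 4 (0.12 log units; within the scatter). The estimate for compound 4 is 8 nM, between 3 nM and 25 nM.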

Compound 4, half-maximal inhibitory concentration: 6 nM
The estimate for compound 4 lay 1.3-fold (0.12 log units) above the measured number; measured number inside the range.
By their numbers in this assay, from the lowest: compound 3; then compounds 1 and 4 (each within the scatter of the next); then compound 2.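

In this assay, within the data shown here, with the 2,2,6,6-tetramethyloxan-4-yl group held constant, 5-chlorothiophen-3-yl in place of 6-methylpyridin-3-yl gives no change at the digits printed from compound 1 to compound 4 (within the scatter), the first clean reading at this position. The earlier compounds shown here could not provide this reading: compound 2 and compound 3 differ only on the oxane, while compound 1 and compound 3 differ in two places at once. Here a five-membered aromatic ring with sulfur and a chlorine stands in place of a six-membered aromatic ring with nitrogen and a methyl group, and this exchange of ring size and hetero atom leaves the two numbers within the scatter of each other, though no measurement is at hand to explain this equivalence.

As far as these compounds go, whether the two aryl groups also read alike alongside the 2,2-dimethyloxan-4-yl or 2-isopropyloxan-4-yl group remains open, as the comparison stands on a single oxane. Also open, from the compounds shown here alone, is how an unsubstituted thiophen-3-yl, or an aryl group carrying an amine or a carboxylic acid, would read at this position.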